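Methylamino to ethylamino on the shared core

A few compounds are considered here, and "the series" means these few. Any claim that something is new, unique, unknown or untested is made for them only; others in the source may bear on it.

In a functional assay on A549 cells (Homo sapiens) for antiproliferative activity, read by MTT assay, with a stated time of 48 h (a higher number here means a weaker inhibitor, a lower number a stronger inhibitor), compound 1 (`C=C(c1ccc(OC)cc1NC(=O)CN)c1ccc(OC)c2c1C=CC(C)(C)O2`) gives 90 nM and compound 2 (`C=C(c1ccc(OC)cc1NC(=O)CNC)c1ccc(OC)c2c1C=CC(C)(C)O2`) gives 320 nM as the higher of the two numbers. Compound 3 (`C=C(c1ccc(OC)cc1NC(=O)CNCC)c1ccc(OC)c2c1C=CC(C)(C)O2`) turns methylamino into ethylamino, with methyl in place of hydrogen on a saturated chain carbon bound to an amine nitrogen. Within the data shown here, the one measured step bearing on this is a 3.6-fold higher number from compound 1 to compound 2 (0.55 log units; beyond the scatter) (modest, beyond the scatter), which also adds a methyl, there on the amine nitrogen itself. In this assay a further modest step toward a higher number is therefore expected. The step expected is a 1.6-fold higher number from compound 2 to compound 3 (0.19 log units; within the scatter) on this estimate. Compound 3 is expected at 500 nM (estimated range 180 nM to 1400 nM).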

Compound 3, half-maximal inhibitory concentration: 1870 nM
Compound 3: middle estimate off by 3.7-fold (0.57 log units), on the low side; measured number outside the range, above it.
By their numbers in this assay, from the lowest: compound 1; then compound 2; then compound 3.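

In this assay, the second added carbon also moves the number up, by a 5.8-fold higher number from compound 2 to compound 3 (0.77 log units; beyond the scatter), so the change at this position does not stop at the methyl step. Taken from the unsubstituted amine, ethyl in place of hydrogen on the amine nitrogen gives a 21-fold higher number from compound 1 to compound 3 (1.32 log units; beyond the scatter), and the order across the three compounds follows the size of the substituent on that nitrogen, with none going against it. Nothing available explains these steps. Going by these compounds, whether a propyl chain continues this rise stays open, as does the standing of a dimethylamino group at this position.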